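Methyl for difluoromethyl at the low end of the series

This account rests on a few compounds, and the source may have more. Where it says the series, first, only, none or still open, it means among the compounds named here.

Three measured compounds frame the series in an ADME assay on the whole organism (plasma, Homo sapiens) for protein binding, read by LC-MS, with a stated time of 24 h; on this read-out lower numbers stand for a smaller free fraction and higher numbers for a larger free fraction. Compound 1 (`CN(C(=O)OCc1c(-c2ccc(O[C@H]3CCC[C@H](C(=O)O)C3)cc2)nnn1C)C1CCCC1`) gives 0.033, compound 2 (`Cc1noc(-c2ccc(O[C@H]3CCC[C@H](C(=O)O)C3)cc2)c1CNC(=O)OCCC(C)(C)C`) gives 0.006, and compound 3 (`CN(CC1CCC1)C(=O)OCc1c(-c2ccc(O[C@H]3CCC[C@H](C(=O)O)C3)c(C(F)F)n2)nnn1C`) gives 0.001. Compound 3 is therefore the lowest of the three, and the values of both other compounds lie above it by more than the scatter.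

Compound 4 (`Cc1nc(-c2nnn(C)c2COC(=O)N(C)CC2CCC2)ccc1O[C@H]1CCC[C@H](C(=O)O)C1`) departs from compound 3 at one place: methyl in place of difluoromethyl on an aromatic carbon, next to the ring nitrogen (methyl in place of difluoromethyl on an aromatic carbon). Going by the values given here, no two measured compounds differ in only one place, so the series offers no direct precedent for this change. With compound 3 at 0.001 as the starting point, a small rise in this assay is expected, about at the edge of the scatter, and the evidence for its direction is weak. The estimated change is a 2.0-fold higher number from compound 3 to compound 4 (0.30 log units; within the scatter). For compound 4 the estimated value is 0.002, with an expected range of 0.001 to 0.005.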

Compound 4, unbound fraction: 0.033
Estimate against measurement, compound 4: 17-fold (1.22 log units) below, and the stated range ends below it.
By their numbers in this assay, from the lowest: compound 3; then compound 2; then compounds 1 and 4 (each within the scatter of the next).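

At this position, on an aromatic carbon next to the ring nitrogen, methyl in place of difluoromethyl gives the series its first change in one place, and in this assay it produces a 33-fold higher number from compound 3 to compound 4 (1.52 log units; beyond the scatter), a large step beyond the scatter. The exchange leaves the hydrogen-bond donors, hydrogen-bond acceptors and net charge unchanged, yet this single group alone separates the two compounds on this read-out. Nothing at hand accounts for the size of the step.

A hydrogen, a chlorine, a methoxy group or a trifluoromethyl group at this position would show whether the read-out follows a graded trend or whether difluoromethyl stands apart. As far as these compounds go, whether a step of this size persists with a longer chain on the carbamate nitrogen also remains open.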